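Swapping the Charged Ring at the Chain End

The source may report more compounds than this note shows. Statements on the series, on what has been measured and on what is new or still open speak of the compounds shown alone.

Compound 1 `Cc1cc(-n2cc(C(=O)Nc3cc(F)cc(F)c3)c(=O)c3ccc(N(C)C)nc32)ccc1OCCCCCCC[N+]1(C)CCN(C)CC1` and compound 2 `Cc1ccc(-n2cc(C(=O)Nc3cc(F)cc(F)c3)c(=O)c3ccc(N(C)C)nc32)cc1OCCCCCCC[N+]1(C)CCN(C)CC1` are built from the same atoms joined differently; the difference between their two cores is not broken down here. Compound 3 `CC[N+]1(CCCCCCCOc2ccc(-n3cc(C(=O)Nc4cc(F)cc(F)c4)c(=O)c4ccc(N(C)C)nc43)cc2C)CCCC1` carries the core of compound 1 with a changed terminal ring on the long chain, and the counted difference is a group of 7 heavy atoms (6 carbon, 1 nitrogen; one five-membered non-aromatic ring with 1 hetero atom) in place of a group of 8 heavy atoms (6 carbon, 2 nitrogen; one six-membered non-aromatic ring with 2 hetero atoms), on a saturated chain carbon, seven bonds along the chain from an oxygen on an aromatic ring. Compound 4 `CC[N+]1(CCCCCCCOc2cc(-n3cc(C(=O)Nc4cc(F)cc(F)c4)c(=O)c4ccc(N(C)C)nc43)ccc2C)CCCC1` carries the core of compound 2 with the same kind of replacement, counted as a group of 7 heavy atoms (6 carbon, 1 nitrogen; one five-membered non-aromatic ring with 1 hetero atom) in place of a group of 8 heavy atoms (6 carbon, 2 nitrogen; one six-membered non-aromatic ring with 2 hetero atoms), on a saturated chain carbon, seven bonds along the chain from an oxygen on an aromatic ring; the two place descriptions agree word for word, so this is the same change applied to the other core.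

In an assay on LX2 cells for inhibition of COL1A1 promoter (Homo sapiens), read by a luciferase reporter, with a stated time of 24 h, tested at 20 uM (a higher number here means a stronger effect of the compound at the concentration tested, a lower number a weaker effect), compound 1 gives 16.2%. Compound 2 gives 10.4% in this assay, which lies within the scatter of compound 1. Compound 3 gives 44.7%, and the ring swap produced the step of a number 28.5 percentage points higher from compound 1 to compound 3 (beyond the scatter).

Compound 4 is not yet measured in this assay. Among the measured compounds shown here, since the single measured instance of this change is the step of a number 28.5 percentage points higher from compound 1 to compound 3 (beyond the scatter), a step of similar size is expected for the core of compound 2, namely a number 25.6 percentage points higher from compound 2 to compound 4 (beyond the scatter). This expectation rests on one pair only, so its range is wide. Compound 4 is therefore estimated to give 36% in this assay, with the plausible span from 16% to 56%.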

Compound 4, a percentage reported as inhibition, at one concentration (the size of the read-out at that concentration, not a potency): 57%
Beside the measured number, compound 4's estimate is 21 percentage points below it, outside the stated range (above it).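

In this assay, putting the five-membered non-aromatic ring with 1 hetero atom in place of the six-membered non-aromatic ring with 2 hetero atoms, at the end of the long chain, gives a second clear gain on the other core, a number 46.6 percentage points higher from compound 2 to compound 4 (beyond the scatter). The change therefore carried over between the two cores in direction but not in size, and the gain depended on the core it was made on: the same change on two cores in this assay, a number 28.5 percentage points higher (beyond the scatter) from compound 1 to compound 3 and a number 46.6 percentage points higher (beyond the scatter) from compound 2 to compound 4, 18.1 percentage points apart, beyond the scatter of two such steps. This shows that, across these two pairs, the swap raised the read-out on both cores, but it does not show why the two gains differ, what would happen on a further core, or how the effect would change at other concentrations, since each number comes from a single tested concentration.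

What the compounds shown leave open is how a shorter or a longer chain between the aromatic oxygen and the terminal ring would affect the size of this gain on either core. Also open, on these data alone, is whether an open-chain amine or a carboxylic acid at the chain end would keep the read-out of the five-membered ring or lose it.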